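This account rests on a few compounds, and the source may have more. Where it says the series, first, only, none or still open, it means among the compounds named here.

Of the compounds shown here, two built on the same core have been measured in a functional assay on OVCAR-8 cells (Homo sapiens) for inhibition, read by sulforhodamine B assay, with a stated time of 48 h; a lower number here means a stronger inhibitor of growth, a higher number a weaker inhibitor of growth. Compound 1 `COc1cc(-c2nn(-c3cccc(NC(=O)c4cccc(C(F)(F)F)c4)c3)cc2-c2ccncc2)ccc1Cl` gives 2000 nM in this assay. Among the compounds with values here, compound 2 `COc1cc(-c2nn(-c3cccc(NC(=O)c4ccc(Cl)c(C(F)(F)F)c4)c3)cc2-c2ccncc2)ccc1Cl` gives 3350 nM in this assay, and the single step between the two, a 1.7-fold higher number from compound 1 to compound 2 (0.22 log units; within the scatter), is within the scatter, so the numbers of compound 1 and compound 2 cannot be told apart; compound 2 is thus not distinguished from its only neighbour.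

Compound 3 `COc1cc(-c2nn(-c3cccc(NC(=O)Nc4ccc(Cl)c(C(F)(F)F)c4)c3)cc2-c2ccncc2)ccc1Cl` has not yet been measured. It differs from compound 2 by (4-chloro-3-(trifluoromethyl)phenyl)amino in place of 4-chloro-3-(trifluoromethyl)phenyl on a carbonyl carbon. Within the data shown here, the one measured step, a 1.7-fold higher number from compound 1 to compound 2 (0.22 log units; within the scatter), concerns a substituent on an aromatic ring and does not touch the carbonyl carbon, so no measured step bears directly on this change. Among the measured compounds shown here, the expectation therefore rests on the absence of any large step so far: a change not beyond the scatter, a 1.1-fold lower number from compound 2 to compound 3 (0.05 log units; within the scatter). Compound 3 is estimated at 3000 nM, with a range from 1000 nM to 9000 nM.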

Compound 3, concentration for 50% growth inhibition: 1050 nM
Compound 3: the middle estimate sits 2.9-fold (0.46 log units) above what was measured, and the stated range covers the measured number.
By their numbers in this assay, from the lowest: compounds 3, 1 and 2 (each within the scatter of the next, the first and the last beyond it).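

Putting (4-chloro-3-(trifluoromethyl)phenyl)amino in place of 4-chloro-3-(trifluoromethyl)phenyl on the carbonyl carbon gives, in this assay, a 3.2-fold lower number from compound 2 to compound 3 (0.50 log units; beyond the scatter), a modest change but the first in this series to lie beyond the scatter, which shows that the number can move at this position, one the earlier step did not touch. The comparison with the compound lacking the chloro does not separate the pair, since a 1.9-fold lower number from compound 1 to compound 3 (0.28 log units; within the scatter) stays within the scatter. Nothing measured here explains the step from compound 2 to compound 3.

On these data alone, it remains open whether (3-(trifluoromethyl)phenyl)amino on the same carbonyl carbon, without the chloro, would behave as compound 3 does. As far as these compounds go, it is also open whether an oxygen or a methylene in place of the amino nitrogen would keep the step.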